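The compounds below may be only part of what the source reports. "The series", "measured", "known", "first", "only" and "open" are said of these compounds alone.

The compounds are read in a functional assay on A549 cells (Homo sapiens) for cytotoxicity, read by MTT assay, with a stated time of 72 h; on this read-out higher numbers stand for weaker inhibition and lower numbers for stronger inhibition. For the measured compounds named here, there, compound 1 `CNC(=O)c1cc(Oc2ccc(NC(=O)c3nccc(-c4ccccc4)n3)cc2)ccn1` gives 26200 nM, the only actual number so far. Compound 2 `CNC(=O)c1cc(Oc2ccc(NC(=O)c3cc(-c4ccc(C(F)(F)F)cc4)ncn3)cc2F)ccn1` is recorded at > 100000 nM, which is a limit of the assay and not a number. Going by the values given here, compound 1 therefore cannot yet be ranked against a second measured value, and no pair of measured compounds differing in one place is available to show how large a single change tends to be in this assay.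

Compound 3 `CNC(=O)c1cc(Oc2ccc(NC(=O)c3nccc(-c4ccc(OC)cc4)n3)cc2)ccn1` keeps the core of compound 1 and changes it in one place, phenyl to 4-methoxyphenyl: methoxy in place of hydrogen on an aromatic carbon. This puts methoxy in place of hydrogen on an aromatic carbon, para to a large group. Among the compounds with values here, with no measured step to guide the direction, the value of compound 1, 26200 nM, remains the best anchor, and no shift beyond the usual scatter of this assay is expected. The expected 1.0-fold lower number from compound 1 to compound 3 (0.02 log units; within the scatter) is correspondingly small. Compound 3 is estimated at 25000 nM, with an expected range from 9000 nM to 70000 nM.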

Compound 3, half-maximal inhibitory concentration: 11100 nM
The estimate for compound 3 lay 2.3-fold (0.35 log units) above the measured number, and the stated range covers the measured number.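

In this assay, methoxy in place of hydrogen on an aromatic carbon, para to a large group, gives a 2.4-fold lower number from compound 1 to compound 3 (0.37 log units; beyond the scatter). For the compounds shown here, this is the first step between two measured compounds, and it shows that this position of the phenyl ring can take a group carrying heavy atoms and that the change moves the number modestly, but beyond the usual scatter, towards stronger inhibition. Compound 2 differs from the others in more than one place, and its entry is a limit of the assay and not a number, so it adds no step to this reading: the limit of > 100000 nM in this assay, at which 1 of the 3 values shown sits.

A single step gives the direction and size for methoxy alone, and it cannot say why the number falls or whether the same change would act alike on another compound. Going by these compounds, whether the trend carries over to a hydroxy group, an amine, a chlorine atom, a carboxylic acid or a longer chain such as ethoxy or propoxy at the same place remains open, as does the effect of methoxy elsewhere on the ring.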